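The compounds below may be only part of what the source reports. "The series", "measured", "known", "first", "only" and "open" are said of these compounds alone.

In a functional assay on U-937 cells (Homo sapiens) for inhibition, read by MTT assay, with a stated time of 24 h (a higher number here means a weaker inhibitor of growth, a lower number a stronger inhibitor of growth), compound 1 (`O=C1CC(c2ccc(NC(=O)Nc3ccc(Cl)c(C(F)(F)F)c3)cc2)=Nc2cn[nH]c2N1`) gives > 30000 nM, which is a limit and not a number. Compound 2 (`O=C1CC(c2cccc(NC(=O)Nc3ccc(Cl)cc3)c2)=Nc2cn[nH]c2N1`) gives > 30000 nM, which is also only a limit. Compound 3 (`O=C1CC(c2cccc(NC(=O)Nc3ccc(Cl)c(Cl)c3)c2)=Nc2cn[nH]c2N1`) differs from compound 2 by chloro in place of hydrogen on an aromatic carbon, turning 4-chlorophenyl into 3,4-dichlorophenyl. Among the compounds with values here, with the limit of > 30000 nM in this assay, at which 2 of the 2 values shown sit, no measured step guides the expectation in this assay, and only a small move toward stronger inhibition of growth, perhaps none beyond the scatter, is foreseen. The expected step is an at least 1.5-fold lower number from compound 2 to compound 3 (0.17 log units; that floor lies within the scatter). For compound 3 the estimated value is 20000 nM, within an expected range of 5000 nM to 40000 nM.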

Compound 3, concentration for 50% growth inhibition: > 30000 nM
Compound 3: only a limit was reported; the forecaster's own chance of this, stated with the estimate: 60%; at least 1.5-fold (0.17 log units) between middle value and limit.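

In this assay compound 3 gives > 30000 nM, again only a limit, so no step can be read between compound 2 and compound 3. The compounds shown leave open what any single change does to growth inhibition, since none of them has a measured number: the limit of > 30000 nM in this assay, at which 3 of the 3 values shown sit.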